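Two Methoxyphenyl Analogues and a Dimethoxy Newcomer

The source may hold more compounds than are shown below. What is called first, only, known or untested is meant among the compounds shown, and "the series" means these compounds.

Measured so far:
- compound 1 `COc1cccc(Nc2n[nH]c(-c3cccnc3Nc3cc(OC)cc(OC)c3)n2)c1`: 90 nM
- compound 2 `COc1ccc(Nc2n[nH]c(-c3cccnc3Nc3cc(OC)cc(OC)c3)n2)cc1`: 83 nM

In a functional assay on A-431 cells (Homo sapiens) (a lower number here means that less compound is needed, a higher number that more compound is needed for the effect), compound 2 gives the lower of the two numbers, yet its gap to compound 1 is within the scatter, so the two compounds count as equal on these data. Within the data shown here, the one measured step, a 1.1-fold lower number from compound 1 to compound 2 (0.04 log units; within the scatter), moved the methoxy group around the ring without a change beyond the scatter.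

Compound 3 `COc1cc(Nc2ncccc2-c2nc(Nc3cc(OC)ccc3OC)n[nH]2)cc(OC)c1` differs from compound 2 as follows: 2,5-dimethoxyphenyl in place of 4-methoxyphenyl on a nitrogen on an aromatic ring. Among the measured compounds shown here, no measured pair shows a second methoxy group entering, so the single known step only suggests that moving a methoxy group on this ring leaves this assay largely unchanged. The step of a 1.2-fold higher number from compound 2 to compound 3 (0.08 log units; within the scatter) is therefore expected to stay within the scatter. Compound 3 is estimated at 100 nM, within a range from 35 nM to 300 nM.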

Compound 3, half-maximal effective concentration: > 10000 nM
Compound 3 gave a limit, no number; the forecaster's own chance of this, stated with the estimate: 5%; middle value at least 100-fold (2.00 log units) away from the limit.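

Compound 3 gives no number, only a limit of the assay: the limit of > 10000 nM in this assay, at which 1 of the 3 values shown sits. In this assay, the ring on this nitrogen had shown no change beyond the scatter when its single methoxy group moved, but a 2,5-dimethoxyphenyl group gives an at least 120-fold higher number from compound 2 to compound 3 (2.08 log units; beyond the scatter). The same large gap appears when the change is read as methoxy in place of hydrogen on an aromatic carbon, with an at least 110-fold higher number from compound 1 to compound 3 (2.04 log units; beyond the scatter), so this position is far less forgiving than the two earlier compounds suggested.

The compounds shown do not tell whether the extra methoxy group alone or the particular 2,5-pattern of the two methoxy groups goes with this large step. They also leave open how a hydroxyl group, an amine or a carboxylic acid on this ring would read in this assay.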